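A few compounds are considered here, and "the series" means these few. Any claim that something is new, unique, unknown or untested is made for them only; others in the source may bear on it.

Working notes on the series, in which one aromatic carbon of the shared core carries a varied group: compound 1 `Cc1n[nH]c(-c2ncc3c(N(C)C)ccnc3c2O)n1`, compound 2 `Cc1n[nH]c(-c2ncc3c(N4CCCC4=O)ccnc3c2O)n1`, compound 3 `Cc1n[nH]c(-c2ncc3c(N4CCCCS4(=O)=O)ccnc3c2O)n1` and the unmeasured compound 4 `Cc1n[nH]c(-c2ncc3c(-c4ccccc4)ccnc3c2O)n1`.

In an ADME assay on microsomes from liver (Mus musculus) for metabolic stability (on this read-out higher numbers stand for fast clearance and lower numbers for slow clearance), compound 1 gives 14 mL.min-1.g-1 and compound 3 gives 0.6 mL.min-1.g-1, the lower of the two true numbers available. Compound 2 reads < 0.5 mL.min-1.g-1, which is a limit and not a number.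

The change to compound 4 places phenyl on the aromatic carbon opposite the ring nitrogen: a group of 6 heavy atoms (6 carbon; one six-membered aromatic ring of carbon only) in place of a group of 8 heavy atoms (4 carbon, 1 nitrogen, 2 oxygen, 1 sulfur; one six-membered non-aromatic ring with 2 hetero atoms), on an aromatic carbon.

The nearest evidence comes from the other changes at this carbon. Two were large: an at least 28-fold lower number from compound 1 to compound 2 (1.44 log units; beyond the scatter) and a 23-fold lower number from compound 1 to compound 3 (1.37 log units; beyond the scatter). The third, an at least 1.2-fold higher number from compound 2 to compound 3 (0.07 log units; that floor lies within the scatter), has a floor within the scatter. In all three compounds the group is joined through nitrogen, whereas phenyl is joined through carbon, so these steps bear on the change only indirectly.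

Compound 3 gives 0.6 mL.min-1.g-1. Compound 2 sits at the limit of the assay, and compound 3 lies close to it, which leaves little room for a fall. A rise beyond the scatter is therefore expected, probably large but not clearly past the level of compound 1.

The expected step is an 8.3-fold higher number from compound 3 to compound 4 (0.92 log units; beyond the scatter). For compound 4 the estimated value is 5 mL.min-1.g-1, with an expected range of 1 mL.min-1.g-1 to 20 mL.min-1.g-1.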

Compound 4, intrinsic clearance in microsomes: 9.4 mL.min-1.g-1
Compound 4: the middle estimate sits 1.9-fold (0.27 log units) below what was measured; the range from low to high includes it.
By their numbers in this assay, from the lowest: compound 3; then compounds 4 and 1 (each within the scatter of the next). At a limit, below all of these: compound 2.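

In this assay, going by these compounds alone, phenyl joined through carbon on the aromatic carbon opposite the ring nitrogen gives the first high number among the ring-bearing groups, with a 16-fold higher number from compound 3 to compound 4 (1.19 log units; beyond the scatter), which shows that a ring at this position does not by itself go with a low number. Phenyl and dimethylamino are not separated, with a 1.5-fold lower number from compound 1 to compound 4 (0.17 log units; within the scatter), and that step lies within the scatter, while the two groups that carry carbonyl or sulfonyl oxygens remain apart from both. Compound 2 reads as a limit and not a number, and an at least 18-fold higher number from compound 2 to compound 4 (1.27 log units; beyond the scatter) is read as a floor: the limit of < 0.5 mL.min-1.g-1 in this assay, at which 1 of the 4 values shown sits.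

The compounds shown leave open whether the high number of compound 4 goes with the carbon link or with the lack of carbonyl or sulfonyl oxygens, since both change together in this step. A piperidin-1-yl group, joined through nitrogen without a carbonyl, or a cyclohexyl group, joined through carbon without an aromatic ring, would pull these apart and show whether the aromatic ring of phenyl matters here.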